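Lengthening the side chain on the shared core

A few compounds are considered here, and "the series" means these few. Any claim that something is new, unique, unknown or untested is made for them only; others in the source may bear on it.

Measured compounds:
- compound 1, `CCCOCNc1n[n+]([O-])c2cc(OC)ccc2[n+]1[O-]`: 2880 nM
- compound 2, `CCCCCOCNc1n[n+]([O-])c2ccccc2[n+]1[O-]`: 17000 nM
- compound 3, `CCCCCOCNc1n[n+]([O-])c2cc(OC)ccc2[n+]1[O-]`: 12900 nM

These three compounds were tested in a functional assay on SMMC-7721 cells (Homo sapiens) for cytotoxicity, read by MTT assay, with a stated time of 72 h; on this read-out lower numbers stand for stronger inhibition and higher numbers for weaker inhibition. Among them compound 2 gives the highest number; the gap to compound 3 is within the scatter, while the gap to compound 1 is beyond it. Compound 4, `CCCCCCCOCNc1n[n+]([O-])c2ccccc2[n+]1[O-]`, has not been measured. It differs from compound 2 by ethyl in place of hydrogen on a saturated chain carbon, five bonds along the chain from an oxygen on a saturated carbon.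

Within the data shown here, the one measured step of the same kind, a 4.5-fold higher number from compound 1 to compound 3 (0.65 log units; beyond the scatter), added the ethyl closer to the oxygen and pushed the number up. Compound 2 and compound 3 show that a methoxy on the aromatic carbon hardly matters here. The chain lengthening is therefore expected to raise the number again, by a modest step of a 1.8-fold higher number from compound 2 to compound 4 (0.25 log units; within the scatter), though one within the scatter cannot be ruled out. Compound 4 is estimated at 30000 nM, within 12000 nM to 75000 nM.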

Compound 4, half-maximal inhibitory concentration: 7030 nM
Estimate against measurement, compound 4: 4.3-fold (0.63 log units) above; the measured number lies below the stated range.
By their numbers in this assay, from the lowest: compound 1; then compounds 4, 3 and 2 (each within the scatter of the next, the first and the last beyond it).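

Lengthening the chain by an ethyl at this position does not always weaken the compound: here the number falls, a 2.4-fold lower number from compound 2 to compound 4 (0.38 log units; beyond the scatter), and a lower number means stronger inhibition. So the longer chain does not push the number in one direction, and the step seen earlier cannot be carried over to this position or core. The two steps disagree by more than scatter can explain: the same change on two cores in this assay, a 4.5-fold higher number (0.65 log units; beyond the scatter) from compound 1 to compound 3 and a 2.4-fold lower number (0.38 log units; beyond the scatter) from compound 2 to compound 4, 11-fold (1.03 log units) apart, beyond the scatter of two such steps

On these data alone, whether the opposite directions depend on chain length or on the methoxy on the core stays open. So does what a still longer chain or an amine in its place would do.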